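A few compounds are considered here, and "the series" means these few. Any claim that something is new, unique, unknown or untested is made for them only; others in the source may bear on it.

Measured compounds:
compound 1 `CNC(=O)[C@@]12C[C@@H]1[C@@H](n1cnc3c(NC)nc(C#Cc4ccccc4)nc31)[C@H](O)[C@@H]2O` — in an assay on CHO cells for displacement of a labelled ligand from adenosine receptor A1 (Homo sapiens), read by scintillation counting, with a stated time of 60 min, tested at 10 uM (a higher number here means more inhibition at the concentration tested (going by the name of the read-out), a lower number less inhibition), compound 1 gives 18%
compound 2 `CNC(=O)[C@@]12C[C@@H]1[C@@H](n1cnc3c(NC)nc(C#Cc4cccc(F)c4)nc31)[C@H](O)[C@@H]2O` — compound 2 gives 14%
compound 3 `CNC(=O)[C@@]12C[C@@H]1[C@@H](n1cnc3c(NC)nc(C#Cc4ccc(OC)cc4)nc31)[C@H](O)[C@@H]2O` — compound 3 gives 10%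

Compound 3 sits at the low end of the three numbers, but the distances to it, a number 8 percentage points lower from compound 1 to compound 3 (within the scatter) and a number 4 percentage points lower from compound 2 to compound 3 (within the scatter), are both within the scatter, so the three compounds are not separable in this assay.

Compound 4 `CNC(=O)[C@@]12C[C@@H]1[C@@H](n1cnc3c(NC)nc(C#Cc4cccc(C(F)(F)F)c4)nc31)[C@H](O)[C@@H]2O` is not yet measured. Its change from compound 3: 3-(trifluoromethyl)phenyl in place of 4-methoxyphenyl on a triple-bonded carbon. Going by the values given here, the closest precedent is the aryl swap a number 4 percentage points lower from compound 2 to compound 3 (within the scatter), and the substitution of an aromatic hydrogen a number 4 percentage points lower from compound 1 to compound 2 (within the scatter); both within the scatter. No change beyond the scatter is therefore expected for compound 4, with an estimated step of a number 4 percentage points higher from compound 3 to compound 4 (within the scatter). Compound 4 is estimated at 14%, range 4% to 26%.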

Compound 4, a percentage reported as inhibition, at one concentration (the size of the read-out at that concentration, not a potency): 10%
For compound 4 the middle estimate is 4 percentage points above the measured one; measured number inside the range.
By their numbers in this assay, from the lowest: compounds 3, 4, 2 and 1 (each within the scatter of the next).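

In this assay the aryl swap on the triple-bonded carbon, with a hydrogen-bond acceptor leaving and none entering, gives no change at the digits printed from compound 3 to compound 4 (within the scatter) and so does not separate the two groups. Trifluoromethyl in place of fluoro gives a number 4 percentage points lower from compound 2 to compound 4 (within the scatter) and trifluoromethyl in place of hydrogen gives a number 8 percentage points lower from compound 1 to compound 4 (within the scatter), so this group also leaves all four compounds unseparated. Nothing available explains these numbers.

Open, on these data alone, is whether any group on the triple-bonded carbon moves this number beyond the scatter, such as an aryl ring carrying an amine or a carboxylic acid, or a longer chain in place of the aryl ring.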